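This account rests on a few compounds, and the source may have more. Where it says the series, first, only, none or still open, it means among the compounds named here.

Compound 3 `Cc1ccc(Nc2nc(C)c(C(=O)/C=C/c3ccccc3)s2)cc1` stands at a limit of a functional assay on PC-3 cells (Homo sapiens) for cytotoxicity, read by MTT assay; on this read-out lower numbers stand for stronger inhibition and higher numbers for weaker inhibition: in this assay compound 3 gives > 25000 nM, which is a limit of the assay and not a number. Compound 1 `Cc1ccc(Nc2nc(C)c(C(=O)/C=C/c3ccc(Cl)cc3)s2)cc1` gives > 25000 nM in this assay, again only a limit. Compound 2 `COc1ccc(/C=C/C(=O)c2sc(Nc3ccc(Cl)c(Cl)c3)nc2C)cc1` gives > 25000 nM in this assay, also a limit. Within the data shown here, all three values sit at the same limit (the limit of > 25000 nM in this assay, at which 3 of the 3 values shown sit), so the single one-place step, a step that the two limits leave unreadable from compound 1 to compound 3, cannot be read. Compound 4 `Cc1cccc(Nc2nc(C)c(C(=O)/C=C/c3ccccc3)s2)c1` differs from compound 3 by 3-methylphenyl in place of 4-methylphenyl on a nitrogen on an aromatic ring. Among the measured compounds shown here, no measured step bears on this change, and nothing reads above the limit, so a limit reading is expected again. The expected step is a step that the limit leaves unreadable from compound 3 to compound 4. For compound 4 the estimate in this assay is 35000 nM, in a range from 12000 nM to 100000 nM.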

Compound 4, half-maximal inhibitory concentration: 11700 nM
For compound 4 the middle estimate is 3.0-fold (0.48 log units) above the measured one, and the stated range ends above it.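

In this assay the series gains its first readable step, with 3-methylphenyl in place of 4-methylphenyl on a nitrogen on an aromatic ring: an at least 2.1-fold lower number from compound 3 to compound 4 (0.32 log units; beyond the scatter). Among these compounds, the place of the methyl on this phenyl therefore changes the reading, which the earlier compounds could not show. Compound 4 alone reads as a number, and the other compounds stay at a limit: the limit of > 25000 nM in this assay, at which 3 of the 4 values shown sit.

Open, on these data alone, is whether 3-ethylphenyl or 3-methoxyphenyl on this nitrogen would hold or extend the step. Also open, as far as these compounds go, is whether the 4-chlorophenyl of compound 1 would change the reading alongside 3-methylphenyl.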